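Swapping iodo for methoxy on the aryl carbamate

The source may report more compounds than this note shows. Statements on the series, on what has been measured and on what is new or still open speak of the compounds shown alone.

Three compounds have been measured in a functional assay on RAW264.7 cells (Mus musculus) for inhibition, with a stated time of 30 min; a lower number here means a stronger inhibitor, a higher number a weaker inhibitor:
- compound 1 `C=C1C(=O)OC[C@@H]1CCOC(=O)Nc1ccc(I)cc1` gives 790 nM
- compound 2 `C=C1C(=O)OC[C@H]1CCOC(=O)Nc1ccc(I)cc1` gives 490 nM
- compound 3 `C=C1C(=O)OC[C@@H]1CCOC(=O)Nc1cc(C(F)(F)F)cc(C(F)(F)F)c1` gives 800 nM

Compound 1 sits second highest of the three numbers. Its nearest neighbour is compound 3, whose value lies within the scatter of its own, and compound 2 lies furthest away, though still within the scatter. Within the data shown here, the one step that can be followed between measured compounds, a 1.6-fold lower number from compound 1 to compound 2 (0.21 log units; within the scatter), is a change in configuration alone (the fact that compounds 1 and 2 differ only in the configuration as drawn); the two compounds share every atom and bond and differ only at one stereocentre.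

The unmeasured compound 4 `C=C1C(=O)OC[C@@H]1CCOC(=O)Nc1ccc(OC)cc1` keeps the core of compound 1 and changes the aryl group: methoxy in place of iodo on an aromatic carbon. Among the measured compounds shown here, no measured step bears on this change. The stereo step from compound 1 to compound 2 concerns a different part of the molecule and says nothing about the aryl substituent, and the pair of compound 1 and compound 3, which does differ on the aryl ring, shows two values within the scatter of each other without a counted step.

With nothing to anchor the direction, the expected step of a 1.1-fold higher number from compound 1 to compound 4 (0.06 log units; within the scatter) is none beyond the scatter. Compound 4 is therefore estimated at 900 nM, with a range from 300 nM to 2700 nM in this assay.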

Compound 4, half-maximal inhibitory concentration: 1090 nM
The estimate for compound 4 lay 1.2-fold (0.08 log units) below the measured number; measured number inside the range.
By their numbers in this assay, from the lowest: compounds 2, 1, 3 and 4 (each within the scatter of the next, the first and the last beyond it).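

In this assay, methoxy in place of iodo gives a 1.4-fold higher number from compound 1 to compound 4 (0.14 log units; within the scatter), so this exchange on the aromatic carbon, para to a large group, produces no difference that can be told from the scatter. Among these compounds, this is the first step that can be followed on the aryl group itself, since the earlier step concerned only the configuration of the shared core. It shows that one iodine, with no hydrogen-bond acceptor, can give way to methoxy, with 2 heavy atoms and 1 hydrogen-bond acceptor, and leave the number within the scatter, although nothing known about these compounds bears on why that is so.

This single pair cannot show whether an amine, a carboxylic acid or a longer alkoxy chain at the same place would move the number beyond the scatter. It also leaves open whether methoxy would give a similar result on the configuration of compound 2, which carries iodo at this position.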